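Hydrazone aryl swap on a triazine sulfonamide scaffold

The compounds below may be only part of what the source reports. "The series", "measured", "known", "first", "only" and "open" are said of these compounds alone.

Measured so far:
compound 1, `NS(=O)(=O)c1ccc(Nc2nc(N/N=C/c3ccc(C(F)(F)F)cc3)nc(Nc3ccccc3)n2)cc1`, 3690 nM
compound 2, `Cc1nn(-c2ccccc2)cc1/C=N/Nc1nc(Nc2ccccc2)nc(Nc2ccc(S(N)(=O)=O)cc2)n1`, 2550 nM

Of the compounds shown here, two sharing the same core have been tested in a functional assay on OVCAR-4 cells (Homo sapiens) for inhibition, read by sulforhodamine B assay, with a stated time of 48 h; on this read-out higher numbers stand for weaker inhibition of growth and lower numbers for stronger inhibition of growth. Compound 1 gives 3690 nM in this assay, and compound 2 gives 2550 nM. For the measured compounds named here, the only measured step, a 1.4-fold lower number from compound 1 to compound 2 (0.16 log units; within the scatter), shows that exchanging the aryl group on the hydrazone carbon between these two compounds leaves the number essentially unchanged, so compound 2 stands within the scatter of compound 1 and neither can be called the more potent.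

Compound 3, `NS(=O)(=O)c1ccc(Nc2nc(N/N=C/c3ccccn3)nc(Nc3ccccc3)n2)cc1`, is not yet measured. It differs from compound 2 in one place: pyridin-2-yl in place of 3-methyl-1-phenyl-1H-pyrazol-4-yl on a carbon with a double bond to nitrogen. Going by the values given here, the step from compound 1 to compound 2 is the only one bearing on this change, since it also varied the aryl group on the hydrazone carbon, and it stayed within the scatter. On that basis a step beyond the scatter is not expected in this assay, and the number for compound 3 is estimated to stay close to that of compound 2, with a 1.2-fold higher number from compound 2 to compound 3 (0.07 log units; within the scatter). Compound 3 is therefore expected to give about 3000 nM, within a range from 1000 nM to 9000 nM.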

Compound 3, concentration for 50% growth inhibition: 440 nM
Beside the measured number, compound 3's estimate is 6.8-fold (0.83 log units) above it; measured number outside the range, below it.
By their numbers in this assay, from the lowest: compound 3; then compounds 2 and 1 (each within the scatter of the next).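

In this assay, the group on a carbon with a double bond to nitrogen now proves able to move the number beyond the scatter, with a 5.8-fold lower number from compound 2 to compound 3 (0.76 log units; beyond the scatter) when pyridin-2-yl enters for 3-methyl-1-phenyl-1H-pyrazol-4-yl, and with an 8.4-fold lower number from compound 1 to compound 3 (0.92 log units; beyond the scatter) when it enters for 4-(trifluoromethyl)phenyl. The earlier pair could not show this, as its two groups gave numbers within the scatter of each other, so the position had looked insensitive to the aryl exchange; pyridin-2-yl, a single six-membered aromatic ring with 1 hetero atom, separates from both of those groups. No measurement shown here accounts for this difference.

The three compounds leave open whether the lower number follows the ring nitrogen of pyridin-2-yl or the single ring that replaces the larger groups, a question that unsubstituted phenyl at this position would address. They also leave open whether the place of that nitrogen matters, as pyridin-3-yl and pyridin-4-yl would show, and whether the same exchange holds on other cell lines.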